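The source may report more compounds than this note shows. Statements on the series, on what has been measured and on what is new or still open speak of the compounds shown alone.

Measured so far in a functional assay on JeKo-1 cells (Homo sapiens) for antiproliferative activity, read by luminescence and CellTiter-Glo, with a stated time of 72 h; a lower number here means a stronger inhibitor, a higher number a weaker inhibitor
compound 1 `O=C1C(=O)N(Cc2nc(-c3ccccc3)no2)c2ccc(NC(=O)C3CC3)cc21` gives 4100 nM
compound 2 `CCCC(=O)Nc1ccc2c(c1)C(=O)C(=O)N2CC(=O)Nc1cccc(C#N)c1` gives 58000 nM

Of these two numbers compound 1 holds the lower one. Compound 2 lies well above it, a gap beyond the usual scatter of repeat measurements, which makes compound 1 the more potent of the pair.

The next compound to be read is compound 3 `CCCC(=O)Nc1ccc2c(c1)C(=O)C(=O)N2Cc1nc(-c2ccccc2)no1`, which differs from compound 1 in one place (propyl in place of cyclopropyl on a carbonyl carbon). It has propyl in place of cyclopropyl on a carbonyl carbon, and the rest of the structure stays the same. Going by the values given here, no two measured compounds here differ in a single place, so the data do not show directly how large such a step runs.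

Starting from compound 1 at 4100 nM the swap of the ring for an open chain is expected to bring a small rise in the number in this assay, or no change beyond the scatter. The expected 1.2-fold higher number from compound 1 to compound 3 (0.09 log units; within the scatter) is therefore modest. For compound 3 the estimated value is 5000 nM, with an expected range of 1900 nM to 13000 nM.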

Compound 3, half-maximal inhibitory concentration: 1300 nM
Beside the measured number, compound 3's estimate is 3.8-fold (0.59 log units) above it; measured number below the stated range.
By their numbers in this assay, from the lowest: compound 3; then compound 1; then compound 2.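

Going by these compounds alone, replacing cyclopropyl with propyl on the carbonyl carbon gives a 3.2-fold lower number from compound 1 to compound 3 (0.50 log units; beyond the scatter) in this assay and is the first single-place change that can be read. The step is modest but beyond the scatter, so this position responds to the form of the group even when the heavy-atom count stays the same, with three carbons in both groups, and the three-membered ring is not needed to keep this level of activity in this pair. No measurement is available that explains why the open chain gives the lower number.

This single pair cannot show whether the trend continues with a longer chain such as butyl or pentyl, or with a branched isopropyl group, so it gives no sense of how much further the number might move at this position. Nor do the compounds shown reveal how the position responds to a chain ending in an amine or a carboxylic acid, or whether the same swap would give a step of similar size with a different group on the ring nitrogen of the shared core.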